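Thiazole for Dimethyl-oxazole on the Sulfonamide Nitrogen

A few compounds are considered here, and "the series" means these few. Any claim that something is new, unique, unknown or untested is made for them only; others in the source may bear on it.

Of the compounds shown here, three sharing one core have been measured in a functional assay on AS49-RAW cells (Homo sapiens) for antiproliferative activity, read by sulforhodamine B assay, with a stated time of 48 h; a higher number here means a weaker inhibitor, a lower number a stronger inhibitor. Compound 1 `CC(=O)NS(=O)(=O)c1ccc(N/C(S)=N\c2ccnc3cc(C(F)(F)F)ccc23)cc1` gives 37600 nM. Compound 2 `Cc1cc(NS(=O)(=O)c2ccc(N/C(S)=N\c3ccnc4cc(C(F)(F)F)ccc34)cc2)on1` gives 60200 nM, and compound 3 `Cc1noc(NS(=O)(=O)c2ccc(N/C(S)=N\c3ccnc4cc(C(F)(F)F)ccc34)cc2)c1C` gives 34000 nM. The steps among them are all modest: a 1.6-fold higher number from compound 1 to compound 2 (0.20 log units; within the scatter), a 1.1-fold lower number from compound 1 to compound 3 (0.04 log units; within the scatter) and a 1.8-fold lower number from compound 2 to compound 3 (0.25 log units; within the scatter). Compound 3 therefore stands in the same band as the other two, closest to compound 1 and furthest from compound 2, with neither gap beyond the scatter.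

Compound 4 `O=S(=O)(Nc1nccs1)c1ccc(N/C(S)=N\c2ccnc3cc(C(F)(F)F)ccc23)cc1` differs from compound 3 in one place: 1,3-thiazol-2-yl in place of 3,4-dimethyl-1,2-oxazol-5-yl on a sulfonamide nitrogen. The bearing steps are those that also changed the group on the sulfonamide nitrogen, from compound 1 to compound 2 and from compound 1 to compound 3, and both stayed within the scatter, as did the methyl change from compound 2 to compound 3. Three different groups on this nitrogen gave numbers in one band, so a fourth ring in the same place is expected to do the same, with no step beyond the scatter in this assay in either direction. Compound 4 is thus estimated at 40000 nM, within 15000 nM to 100000 nM, which corresponds to an expected step of a 1.2-fold higher number from compound 3 to compound 4 (0.07 log units; within the scatter).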

Compound 4, half-maximal inhibitory concentration: 27200 nM
For compound 4 the middle estimate is 1.5-fold (0.17 log units) above the measured one; the measured number falls inside the stated range.
By their numbers in this assay, from the lowest: compounds 4, 3, 1 and 2 (each within the scatter of the next, the first and the last beyond it).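

In this assay, putting a sulfur-bearing ring on the sulfonamide nitrogen gives a 1.3-fold lower number from compound 3 to compound 4 (0.10 log units; within the scatter) and a 1.4-fold lower number from compound 1 to compound 4 (0.14 log units; within the scatter), so the thiazole joins the dimethyl-oxazole and the acetyl group in one band and the kind of hetero atom in the ring shows no separable effect against either of them. For the compounds shown here, what the earlier compounds did not show is a 2.2-fold lower number from compound 2 to compound 4 (0.35 log units; beyond the scatter), the first step at this position to pass the scatter, though only modestly, so the groups on this nitrogen are not wholly interchangeable: the two ends of the series can now be told apart, while each neighbouring pair still cannot. Nothing measured here accounts for that small gap between the 3-methyl-1,2-oxazol-5-yl and 1,3-thiazol-2-yl groups.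

The compounds shown leave open whether a group of another kind on this nitrogen, such as an amine, a carboxylic acid or a longer chain, would stay in this band. They also leave open whether a change elsewhere on the shared core would move the number further than these changes on the sulfonamide nitrogen have.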